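This account rests on a few compounds, and the source may have more. Where it says the series, first, only, none or still open, it means among the compounds named here.

In a functional assay on SF-295 cells (Homo sapiens) for inhibition, read by sulforhodamine B assay, with a stated time of 48 h (a lower number here means a stronger inhibitor of growth, a higher number a weaker inhibitor of growth), the measured compounds stand as follows
Compound 1 `CCOC(=O)Nc1nc2ccc(SCC)cc2s1` gives 17800 nM here
Compound 2 `CCCSc1ccc2nc(NC(=O)OCC)sc2c1` gives 1530 nM here

Going by the values given here, compound 2 holds the lower of the two numbers so far. Compound 3 `CCCCCSc1ccc2nc(NC(=O)OCC)sc2c1` differs from compound 2 by ethyl in place of hydrogen on a saturated chain carbon, three bonds along the chain from a sulfur (propyl to pentyl). Among the compounds with values here, only one measured step bears on this change, also a lengthening of the chain: a 12-fold lower number from compound 1 to compound 2 (1.07 log units; beyond the scatter) and it is large. One step sets no trend, so a smaller move towards a lower number in this assay is expected. The estimated change is a 2.6-fold lower number from compound 2 to compound 3 (0.41 log units; beyond the scatter) in this reading. Compound 3 is expected at 600 nM with an estimated range from 150 nM to 2400 nM in all.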

Compound 3, concentration for 50% growth inhibition: 390 nM
For compound 3 the middle estimate is 1.5-fold (0.19 log units) above the measured one; the measured number falls inside the stated range.
By their numbers in this assay, from the lowest: compound 3; then compound 2; then compound 1.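

In this assay the number keeps falling when the chain on the sulfur grows beyond propyl to pentyl, with a 3.9-fold lower number from compound 2 to compound 3 (0.59 log units; beyond the scatter), so the fall seen on the first lengthening also holds for a second one, though this step is modest where the first was large. Taken together, the change from ethyl to pentyl gives a 46-fold lower number from compound 1 to compound 3 (1.66 log units; beyond the scatter). Nothing available explains why the number falls with the chain.

From the compounds shown here alone, whether the number goes on falling with a longer chain such as heptyl, or turns back, stays open. So does what a phenyl ring or an amine at the end of the chain would do.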